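The source may report more compounds than this note shows. Statements on the series, on what has been measured and on what is new or still open speak of the compounds shown alone.

The set gathers three measured compounds and one awaiting measurement, all read in a functional assay on the whole organism (strain Swiss) with Mus musculus as the target, in the maximal electroshock model, with a stated time of 0.25 h; on this read-out higher numbers stand for an effect only at larger amounts of compound and lower numbers for an effect already at smaller amounts. Compound 1 `CCC(C(=O)N1CCN(c2cccc(C(F)(F)F)c2)CC1)N1C(=O)CC(C)C1=O` gives 75.1 mg/kg and compound 2 `CCC(C(=O)N1CCN(c2cccc(Cl)c2)CC1)N1C(=O)CC(C)C1=O` gives 117 mg/kg; the step of a 1.6-fold higher number from compound 1 to compound 2 (0.19 log units; within the scatter) separates them. Compound 3 `CC(C(=O)N1CCN(c2ccccc2C(F)(F)F)CC1)N1C(=O)CC(C)(C)C1=O` stands apart from these two: in this assay it reaches only a limit, > 130 mg/kg, which is a boundary of the measurement rather than a number, as noted in the limit of > 130 mg/kg in this assay, at which 1 of the 3 values shown sits.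

Compound 4 `CC(C(=O)N1CCN(c2ccccc2)CC1)N1C(=O)CC(C)(C)C1=O` differs from compound 3 by a single change, (hydrogen in place of trifluoromethyl on an aromatic carbon). Going by the values given here, the only measured step that touches the same position is the exchange of trifluoromethyl for chloro from compound 1 to compound 2, and that step stayed within the scatter. Removing the trifluoromethyl altogether goes a little further than that exchange, but no shown step suggests a shift beyond the scatter, and compound 3 itself offers only a limit as the starting point.

Compound 4 is therefore expected to sit near the same boundary, with an estimated step that the limit leaves unreadable from compound 3 to compound 4 from compound 3. The estimated value of compound 4 in this assay is 160 mg/kg, expected to lie between 70 mg/kg and 400 mg/kg.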

Compound 4, dose for half-maximal effect: > 130 mg/kg
Compound 4: only a limit was reported; the forecaster's own chance of this, stated with the estimate: 60%; the middle value does not contradict the limit.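

Compound 3 and compound 4 both stop at a limit in this assay, so no step can be read between them: the limit of > 130 mg/kg in this assay, at which 2 of the 4 values shown sit.

The compounds shown leave open where compound 3 and compound 4 truly lie, and whether hydrogen in place of trifluoromethyl changes the read-out at all.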